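The source may report more compounds than this note shows. Statements on the series, on what has been measured and on what is new or still open speak of the compounds shown alone.

Of the compounds shown here, two that share one core have been tested in an assay on isolated protein for inhibition of kallikrein-7 (Homo sapiens), read by fluorescence, with stated times of 10 min and 30 min; a higher number here means a weaker inhibitor, a lower number a stronger inhibitor. Compound 1, `CC1=NC(c2cn(S(C)(=O)=O)c3ccccc23)CN1`, gives in this assay > 100000 nM, which is a limit of the assay rather than a measured number. Compound 2, `CC1=NC(c2cn(S(=O)(=O)c3cccs3)c3ccc(C)cc23)CN1`, gives in this assay 11000 nM. Among the two results shown, compound 2 therefore carries the only finished number, while the other entry sits at the limit of > 100000 nM in this assay, at which 1 of the 2 values shown sits. Compound 3, `CC1=NC(c2cn(S(=O)(=O)c3ccccc3Cl)c3ccc(C)cc23)CN1`, has not yet been measured. It differs from compound 2 in one place: 2-chlorophenyl in place of thiophen-2-yl on a sulfonyl sulfur. Going by the values given here, no step between two measured compounds is available, so the size of the step to compound 3 cannot be read from a comparison and is given here as an expectation only. The expected step is a 1.1-fold lower number from compound 2 to compound 3 (0.04 log units; within the scatter), that is, no change beyond the usual scatter of this assay in either direction. On that basis compound 3 is expected to give in this assay about 10000 nM, within a range from 3000 nM to 40000 nM.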

Compound 3, half-maximal inhibitory concentration: 1200 nM
Compound 3: the middle estimate sits 8.3-fold (0.92 log units) above what was measured; measured number below the stated range.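

In this assay, the group on a sulfonyl sulfur whose other neighbour is the aromatic nitrogen proves able to move the result: putting 2-chlorophenyl in place of thiophen-2-yl gives a 9.2-fold lower number from compound 2 to compound 3 (0.96 log units; beyond the scatter), a step beyond the usual scatter. Going by these compounds alone, this is the first comparison in which two measured compounds differ in one place only, so the size of a change at this position can now be read from data and not merely expected. It also shows that a five-membered aromatic ring with a sulfur atom is not required here, since a six-membered aromatic ring of carbon only, carrying chlorine, gives the lower number, but nothing shown gives a measured reason for this difference.

The change replaces the ring and adds chlorine in a single step, so these compounds cannot separate the two, and plain phenyl at the same place would be needed to tell them apart. Also open, on these data alone, is how this position responds to groups of a different kind, such as a phenyl ring carrying an amine or a carboxylic acid, or a longer alkyl chain on the sulfonyl sulfur.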